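The compounds below may be only part of what the source reports. "The series", "measured", "known", "first", "only" and "open" are said of these compounds alone.

Measured compounds in a functional assay on HeLa cells (Homo sapiens) for cytotoxicity, read by MTT assay, with a stated time of 72 h, tested at 10 uM; a lower number here means less inhibition of growth, a higher number more inhibition of growth at the concentration tested: compound 1 `N/C(=N\NC(=S)N1CCOCC1)c1ccccn1` gives 56.3%; compound 2 `Cc1cccc(/C(N)=N/NC(=S)N2CCSCC2)n1` gives 67.6%; compound 3 `N/C(=N\NC(=S)N1CCSCC1)c1ccccn1` gives 54.5%.

Compound 3 has the lowest of the three numbers. Its nearest neighbour is compound 1, and the change from the morpholin-4-yl ring to the thiomorpholin-4-yl ring on the thiocarbonyl carbon gave a number 1.8 percentage points lower from compound 1 to compound 3 (within the scatter), a step within the scatter. Its furthest neighbour is compound 2, and the removal of the methyl from the aromatic carbon gave a number 13.1 percentage points lower from compound 2 to compound 3 (beyond the scatter), a step beyond the scatter.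

Compound 4 `N/C(=N\NC(=S)N1CCCCC1)c1ccccn1` differs from compound 3 in one place: piperidin-1-yl in place of thiomorpholin-4-yl on a thiocarbonyl carbon. The step that bears on this is the ring swap from compound 1 to compound 3, because a number 1.8 percentage points lower from compound 1 to compound 3 (within the scatter) shows that exchanging one six-membered ring with two hetero atoms for another at the thiocarbonyl carbon left the number essentially unchanged. The step from compound 2 to compound 3 concerns a different place and does not inform this change. No step beyond the scatter is therefore expected in this assay from compound 3 to compound 4; the expected change is a number 0.5 percentage points higher from compound 3 to compound 4 (within the scatter). For compound 4 the estimate in this assay is 55%, with a range from 43% to 67%.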

Compound 4, percent growth inhibition at one concentration: 55.7%
For compound 4 the middle estimate is 0.7 percentage points below the measured one, within the range that was stated.
By their numbers in this assay, from the lowest: compounds 3, 4 and 1 (each within the scatter of the next); then compound 2.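

In this assay, among the compounds shown here, the earlier compounds had carried only rings with two hetero atoms on the thiocarbonyl carbon, and piperidin-1-yl now extends the comparison to a ring with one hetero atom: there is a number 1.2 percentage points higher from compound 3 to compound 4 (within the scatter), and there is a number 0.6 percentage points lower from compound 1 to compound 4 (within the scatter). Both steps lie within the scatter, so neither replacing the ring sulfur of thiomorpholin-4-yl nor replacing the ring oxygen of morpholin-4-yl with carbon gives a readable change at this place, and this holds for the loss of the hydrogen-bond acceptor counted on thiomorpholin-4-yl as well. No measurement is available to explain why these rings cannot be told apart in this read-out.

As far as these compounds go, all three rings at this place are six-membered and non-aromatic, so it remains open what pyrrolidin-1-yl, an open-chain dimethylamino group or 4-methylpiperazin-1-yl would give on the thiocarbonyl carbon. From the compounds shown here alone, it is also open whether the methyl on the aromatic carbon, whose removal gave a number 13.1 percentage points lower from compound 2 to compound 3 (beyond the scatter), would count for as much alongside piperidin-1-yl.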